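A few compounds are considered here, and "the series" means these few. Any claim that something is new, unique, unknown or untested is made for them only; others in the source may bear on it.

Compounds measured so far:
compound 1, `CCCCCCCCCCCCCCCCOP(=O)(O)OCCSC(=S)N1CCCCC1` — > 100000 nM
compound 2, `CCCCCCCCCCOP(=O)(O)OCCSC(=S)N1CCCC1` — > 100000 nM
compound 3, `CCCCCCCCCCOP(=O)(O)OCCSC(=S)N1CCN(C)CC1` — > 100000 nM

In an ADME assay on HEK293 cells (Homo sapiens) for inhibition, read by MTT assay, with stated times of 18 h and 4 h (on this read-out lower numbers stand for stronger inhibition and higher numbers for weaker inhibition), compound 1 gives only a limit, > 100000 nM. Compound 2 gives only a limit in this assay as well, > 100000 nM. Compound 3 likewise gives only a limit, > 100000 nM. Among the compounds with values here, every value shown thus sits at the limit of > 100000 nM in this assay, at which 3 of the 3 values shown sit, so compound 2 stands nowhere in particular on the scale: its position is known only as a limit, and the one measured step, a step that the two limits leave unreadable from compound 2 to compound 3, cannot be sized from it.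

Compound 4, `CCCCCCCCOP(=O)(O)OCCSC(=S)N1CCCC1`, has not yet been measured. It differs from compound 2 as follows: hydrogen in place of ethyl on a saturated chain carbon, eight bonds along the chain from an oxygen on an unsaturated carbon. No measured step bears on this part of the chain, and the step from compound 2 to compound 3 is unreadable, so nothing shown gives a direction. The step that the limit leaves unreadable from compound 2 to compound 4 is therefore expected to be none beyond the scatter, with compound 4 most likely returning another limit. Compound 4 is estimated at 150000 nM, in a range from 50000 nM to 500000 nM.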

Compound 4, half-maximal inhibitory concentration: 28300 nM
Compound 4: middle estimate off by 5.3-fold (0.72 log units), on the high side, outside the stated range (below it).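

In this assay, hydrogen in place of ethyl on a saturated chain carbon, eight bonds along the chain from an oxygen on an unsaturated carbon, gives an at least 3.5-fold lower number from compound 2 to compound 4 (0.54 log units; beyond the scatter). The size of this step is only a lower bound, since compound 2 has a limit and not a number, so the true change may be larger. This is the first change in the series seen to move the read-out, and compound 4 is the first compound to give a number rather than a limit: the limit of > 100000 nM in this assay, at which 3 of the 4 values shown sit.

On these data alone, the step from compound 2 to compound 3 still cannot be read, so the effect of changing the ring on the thiocarbonyl carbon remains unknown. As far as these compounds go, whether a still shorter chain, or an amine or a carboxylic acid at this place on the chain, would lower the number further also stays open.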